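Methyl on the phenyl ring of compound 2

The compounds below may be only part of what the source reports. "The series", "measured", "known", "first", "only" and "open" are said of these compounds alone.

Compound 1 `CCC(=O)Nc1sc2c(c1C#N)CCCC2` gives 12000 nM in a functional assay on RKE cells for antagonist activity at Vasoactive intestinal polypeptide receptor 1 (Rattus norvegicus), read by HTRF and cAMP accumulation, with stated times of 10 min and 30 min; a higher number here means a weaker inhibitor, a lower number a stronger inhibitor.
Compound 2 `N#Cc1c(NC(=O)CCc2ccccc2)sc2c1CCCC2` gives 290 nM in this assay.

Among the measured compounds shown here, compound 2 stands lowest of the two numbers; the only measured step in the set is a 41-fold lower number from compound 1 to compound 2 (1.62 log units; beyond the scatter). Compound 3 `Cc1ccccc1CCC(=O)Nc1sc2c(c1C#N)CCCC2` carries methyl in place of hydrogen on an aromatic carbon. For the measured compounds named here, no measured step covers this exact change; the step from compound 1 to compound 2 concerns the phenyl itself and is the only guide. A change no larger than the scatter is therefore expected for compound 3 in this assay, with an estimate of 250 nM and a range of 80 nM to 800 nM. This corresponds to an expected step of a 1.2-fold lower number from compound 2 to compound 3 (0.06 log units; within the scatter).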

Compound 3, half-maximal inhibitory concentration: 11000 nM
Compound 3: the middle estimate sits 44-fold (1.64 log units) below what was measured; measured number above the stated range.
By their numbers in this assay, from the lowest: compound 2; then compounds 3 and 1 (each within the scatter of the next).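

A single methyl on an aromatic carbon, ortho to a large group, is far from neutral in this assay (a 38-fold higher number from compound 2 to compound 3 (1.58 log units; beyond the scatter)). With 2-methylphenyl on the chain, the gain seen with phenyl no longer appears (a 1.1-fold lower number from compound 1 to compound 3 (0.04 log units; within the scatter)). The earlier step therefore reflected phenyl alone and does not extend to this methylated ring.

On these data alone, whether fluorine or chlorine at this same carbon would act like methyl remains open, as does the effect of a longer chain between the carbonyl and the phenyl. No supporting measurement bears on this result.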